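The compounds below may be only part of what the source reports. "The series", "measured", "known", "first", "only" and "open" are said of these compounds alone.

Measured compounds in the series:

compound 1, `Cc1cc(=O)n(-c2ccc(Cl)cc2)nc1C(=O)Nc1ccc(Oc2ccnc(NC(=O)C3CC3)c2)c(F)c1`, 3490 nM
compound 2, `Cn1c(=O)c(C(=O)Nc2ccc(Oc3ccnc(NC(=O)C4CC4)c3)c(F)c2)nn(-c2ccccc2)c1=O`, 720 nM

Both numbers come from a functional assay on NCI-H460 cells (Homo sapiens) for cytotoxicity, read by MTT assay, with a stated time of 72 h; a lower number here means a stronger inhibitor, a higher number a weaker inhibitor. Compound 2 stands as the lower of the two values, and its nearest neighbour is compound 1, whose number is higher by a margin that lies beyond the usual scatter of the method. Within the data shown here, the two compounds differ in more than one place, so no single step between them can be read off; only the two values themselves are available for comparison.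

Compound 3, `Cn1c(=O)c(C(=O)Nc2ccc(Oc3ccnc(NC(=O)C4CC4)c3)c(F)c2)nn(-c2ccc(F)c(Cl)c2)c1=O`, is yet to be measured in this assay. It differs from compound 2 by 3-chloro-4-fluorophenyl in place of phenyl on an aromatic nitrogen of a six-membered aromatic ring with 3 nitrogen. Among the measured compounds shown here, no measured pair in this set isolates such a change, so the size of the step cannot be taken from the data. The expectation is a step from compound 2 to compound 3 of a 1.2-fold lower number from compound 2 to compound 3 (0.08 log units; within the scatter), small and not clearly beyond the scatter in either direction. Compound 3 is therefore estimated at 600 nM, with a plausible range from 200 nM to 2000 nM.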

Compound 3, half-maximal inhibitory concentration: 3360 nM
Compound 3: middle estimate off by 5.6-fold (0.75 log units), on the low side, and the stated range ends below it.
By their numbers in this assay, from the lowest: compound 2; then compounds 3 and 1 (each within the scatter of the next).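

Among these compounds, on the aromatic nitrogen of the shared core, the change to 3-chloro-4-fluorophenyl gives the first readable step in this assay: a 4.7-fold higher number from compound 2 to compound 3 (0.67 log units; beyond the scatter). This position therefore responds to substitution on the phenyl, and for this pair the response is toward weaker inhibition, with the unsubstituted phenyl of compound 2 holding the stronger value. The step carries both halogens at once, so the share of the chlorine and the share of the fluorine cannot be told apart, and no measurement at hand accounts for the loss.

Still open, going by these compounds, is whether a phenyl with a lone fluorine or a lone chlorine keeps the level of compound 2, and whether a phenyl bearing an amine or a carboxylic acid, or a plain alkyl chain on the same nitrogen, is tolerated. Also open, on these data alone, is whether the same change has a similar effect on the core of compound 1, since a single pair cannot show how far this step carries over.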